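The source may hold more compounds than are shown below. What is called first, only, known or untested is meant among the compounds shown, and "the series" means these compounds.

Measured compounds in an assay on cells for inhibition of cytochrome P450 11B2, mitochondrial (Homo sapiens), read by HPLC, with a stated time of 90 min; a higher number here means a weaker inhibitor, a lower number a stronger inhibitor:

Compound 1, `N#Cc1ccc2nc(-c3cncnc3C(F)F)n(C3CC3)c2c1`, gives 9 nM.
Compound 2, `N#Cc1ccc2nc(-c3cncnc3C(F)(F)F)n(C3CC3)c2c1`, gives 16 nM.
Compound 3, `N#Cc1ccc2nc(-c3cncnc3C(F)F)n(C3CC3)c2n1`, gives 29 nM.

The three compounds share a cyclopropyl-bearing bicyclic core carrying a nitrile, joined to a second aromatic ring. Compound 1 and compound 2 differ in one place only: fluoro in place of hydrogen on a saturated chain carbon bound to an aromatic carbon and two fluorine atoms. This change produced a 1.8-fold higher number from compound 1 to compound 2 (0.25 log units; within the scatter), a step that stays within the usual scatter of this assay, so compound 1 and compound 2 cannot be set in order against each other on this evidence.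

Compound 3 carries the same difluoromethyl group as compound 1 but sits on a different core; how the core of compound 3 differs from the core of compound 1 is not broken down here. Against compound 2 its number lies within the scatter, while against compound 1 it lies beyond it.

Compound 4, `N#Cc1ccc2nc(-c3cncnc3C(F)(F)F)n(C3CC3)c2n1`, has not been measured in this assay. It relates to compound 3 exactly as compound 2 relates to compound 1: fluoro in place of hydrogen on a saturated chain carbon bound to an aromatic carbon and two fluorine atoms, the same change at the same place. Among the measured compounds shown here, the only guide to its size is the step from compound 1 to compound 2, which was small. On that basis compound 4 is expected to follow compound 3 with a step of a 1.7-fold higher number from compound 3 to compound 4 (0.24 log units; within the scatter). Compound 4 is therefore estimated at 50 nM, with a likely range from 25 nM to 100 nM.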

Compound 4, half-maximal inhibitory concentration: 24 nM
Estimate against measurement, compound 4: 2.1-fold (0.32 log units) above; measured number outside the range, below it.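

Repeated on a second core, the change from difluoromethyl to trifluoromethyl gives a 1.2-fold lower number from compound 3 to compound 4 (0.08 log units; within the scatter) in this assay, so the two compounds of this pair cannot be set in order against each other. Set beside the same change on the first core, the new step does not separate from the earlier one: the same change on two cores in this assay, a 1.8-fold higher number (0.25 log units; within the scatter) from compound 1 to compound 2 and a 1.2-fold lower number (0.08 log units; within the scatter) from compound 3 to compound 4, 2.1-fold (0.33 log units) apart, within the scatter of two such steps. Among the compounds shown here, this shows that in these two pairs the change stayed within the scatter on both cores and that no difference between the cores can be claimed for it, but with only two pairs in one assay it does not show that the change would behave the same way on any further core, or that the two steps are truly identical.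

The compounds shown leave open how a methyl group, an ethyl group or a chlorine atom would read in place of the fluorinated group on either core, and so how far that place tolerates anything other than difluoromethyl and trifluoromethyl. They also leave open what an amide or a carboxylic acid in place of the nitrile, or an isopropyl group in place of the cyclopropyl, would do on these cores.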